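Bromo to nitro on the aryl of compound 3

The compounds below may be only part of what the source reports. "The series", "measured", "known", "first", "only" and "open" are said of these compounds alone.

Measured compounds in a functional assay on the whole organism (strain Swiss albino) for inhibition, with Mus musculus as the target, with a stated time of 4 h; a lower number here means that less compound is needed, a higher number that more compound is needed for the effect:
compound 1 `COc1ccccc1-n1c(Nc2nc(-c3ccc([N+](=O)[O-])cc3)cs2)n[nH]c1=S` gives 100 mg/kg
compound 2 `Cc1ccccc1-n1c(Nc2nc(-c3ccc([N+](=O)[O-])cc3)cs2)n[nH]c1=S` gives 100 mg/kg
compound 3 `Cc1ccc(-n2c(Nc3nc(-c4ccc(Br)cc4)cs3)n[nH]c2=S)cc1` gives 300 mg/kg

Compound 3 stands highest of the three numbers; its two neighbours, compound 1 and compound 2, lie at the same lower value, and the gap from compound 3 to either is beyond the scatter. Among the measured compounds shown here, the one measured step, no change at the digits printed from compound 1 to compound 2 (within the scatter), alters only the substituent on the ring that sits on the shared core and leaves the nitro-bearing aryl untouched.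

Compound 4 `Cc1ccc(-n2c(Nc3nc(-c4ccc([N+](=O)[O-])cc4)cs3)n[nH]c2=S)cc1` arises from compound 3 by nitro in place of bromo on an aromatic carbon on an aromatic carbon of a six-membered aromatic ring of carbon only, para to a large group. For the measured compounds named here, no measured step covers this exchange directly. Going by the values given here, what bears on it is that both nitro-bearing compounds, compound 1 and compound 2, give a lower number than the bromo-bearing compound 3, while the single measured step, in a different part of the structure, was flat. Compound 4 keeps the 4-nitrophenyl of compound 1 and compound 2 and carries a methyl-bearing ring like compound 2, so the expectation is a step down in this assay, of the size a 3.0-fold lower number from compound 3 to compound 4 (0.48 log units; beyond the scatter). Compound 4 is therefore estimated at 100 mg/kg, with a range from 50 mg/kg to 300 mg/kg.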

Compound 4, minimum effective dose: 300 mg/kg
Compound 4: middle estimate off by 3.0-fold (0.48 log units), on the low side; the measured number falls inside the stated range.
By their numbers in this assay, from the lowest: compounds 1 and 2 (each within the scatter of the next); then compounds 3 and 4 (each within the scatter of the next).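

In this assay the change from 4-bromophenyl to 4-nitrophenyl gives no change at the digits printed from compound 3 to compound 4 (within the scatter), so with a 4-methylphenyl on the aromatic nitrogen this exchange does not separate the two groups, and the lower numbers of compound 1 and compound 2 cannot be credited to the nitro group alone. The separation appears instead at the aryl on the aromatic nitrogen, where 4-methylphenyl in place of 2-methylphenyl gives a 3.0-fold higher number from compound 2 to compound 4 (0.48 log units; beyond the scatter) and 4-methylphenyl in place of 2-methoxyphenyl gives a 3.0-fold higher number from compound 1 to compound 4 (0.48 log units; beyond the scatter), across the two nitro-bearing compounds only, while methyl in place of methoxy at the same site of the earlier pair gave no change at the digits printed from compound 1 to compound 2 (within the scatter). Nothing available explains either the flat exchange or the steps at the aryl on the aromatic nitrogen.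

Going by these compounds, whether bromo and nitro also read alike with a 2-methylphenyl or 2-methoxyphenyl on the aromatic nitrogen remains open. Also open, on these data alone, is how an amine or a carboxylic acid would read in place of bromo and nitro on the same aromatic carbon, and whether any such group would move the number in either direction.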